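The source may hold more compounds than are shown below. What is called first, only, known or untested is meant among the compounds shown, and "the series" means these compounds.

In an assay for inhibition of prostacyclin synthase (Homo sapiens), using microsomes (a higher number here means a weaker inhibitor, a lower number a stronger inhibitor), compound 1 `N#Cc1ccc(C2OCC(C/C=C\CCC(=O)O)C(c3cccnc3)O2)cc1` gives only the assay limit of > 100000 nM. Compound 2 `N#Cc1ccccc1C1OCC(C/C=C\CCC(=O)O)C(c2cccnc2)O1` likewise reaches only the assay limit of > 100000 nM in this assay. Among the compounds with values here, the single measured step, a step that the two limits leave unreadable from compound 1 to compound 2, therefore has no readable size; what the series shows is the limit of > 100000 nM in this assay, at which 2 of the 2 values shown sit. Compound 3 `O=C(O)CC/C=C\CC1COC(c2ccc([N+](=O)[O-])cc2)OC1c1cccnc1` carries the change (4-nitrophenyl in place of 2-cyanophenyl on a saturated ring carbon). Within the data shown here, no measured step bears directly on this exchange, and the step from compound 1 to compound 2, which also replaces the aryl group on a saturated ring carbon, yields no readable size, so the numbers hold nothing that would place the inhibition of compound 3 inside the measurable range. Compound 3 is accordingly expected to sit at the limit again, the step that the limit leaves unreadable from compound 2 to compound 3 being estimated as no change beyond the scatter. The estimate for compound 3 is 150000 nM, within 40000 nM to 600000 nM.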

Compound 3, half-maximal inhibitory concentration: 13000 nM
Compound 3: middle estimate off by 12-fold (1.06 log units), on the high side; the whole stated range lies above it.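

In this assay, the aryl group on the saturated ring carbon between two ring oxygen atoms proves able to shift the read-out, which the first pair could not show: 4-nitrophenyl in place of 2-cyanophenyl gives an at least 7.6-fold lower number from compound 2 to compound 3 (0.88 log units; beyond the scatter). The cleaner single exchange, nitro in place of cyano on an aromatic carbon, gives an at least 7.6-fold lower number from compound 1 to compound 3 (0.88 log units; beyond the scatter), so the nitrile-to-nitro change alone is enough to bring the series off its limit. Only compound 3 gives a number inside the range of the assay, and the rest of the series stands at a limit: the limit of > 100000 nM in this assay, at which 2 of the 3 values shown sit.

From the compounds shown here alone, the full size of both steps stays open, since compound 1 and compound 2 are known only as limits. Also open, going by these compounds, is whether an amine or a methyl ester on that same aromatic carbon would lower the number as nitro does.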